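From Methyl to Chloro in a Small Series

This account rests on a few compounds, and the source may have more. Where it says the series, first, only, none or still open, it means among the compounds named here.

In a functional assay on KG-1 cells (Homo sapiens) for cytotoxicity, read by luminescence and CellTiter-Glo, with a stated time of 3 days (a higher number here means a weaker inhibitor, a lower number a stronger inhibitor), compound 1 `N#Cc1ccc(NC(=O)c2cc(Cl)ccc2O)cc1` gives 1860 nM, and compound 2 `Cc1cc(C#N)ccc1NC(=O)c1ccc2cccnc2c1O` gives 3240 nM. These two values lie within the usual scatter of each other, so compound 2 stands level with compound 1. Compound 3 `N#Cc1ccc(NC(=O)c2ccc3cccnc3c2O)c(Cl)c1` carries chloro in place of methyl on an aromatic carbon, ortho to a large group and meta to a cyano group (chloro in place of methyl on an aromatic carbon). Within the data shown here, no measured pair shows this swap, so no change beyond the scatter is expected in this assay. The estimated step is a 1.3-fold lower number from compound 2 to compound 3 (0.11 log units; within the scatter), a small one. For compound 3 the estimated value is 2500 nM, with an expected range of 900 nM to 6500 nM.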

Compound 3, half-maximal inhibitory concentration: 3670 nM
Compound 3: middle estimate off by 1.5-fold (0.17 log units), on the low side; low and high end bracket the measured number.
By their numbers in this assay, from the lowest: compounds 1, 2 and 3 (each within the scatter of the next).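

At this aromatic carbon, ortho to a large group and meta to a cyano group, chloro in place of methyl gives a 1.1-fold higher number from compound 2 to compound 3 (0.05 log units; within the scatter) in this assay, so the two groups read level here. Among these compounds, compound 1 and compound 2 differ in more than one place, so only this pair isolates a single change on the shared core. No measurement available here explains this level result. As far as these compounds go, whether an amine or a methoxy group at this carbon would move the number beyond the scatter remains open, and so does the effect of a longer chain such as propyl.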